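Replacing the 1H-indol-2-yl group on a carbonyl carbon

The compounds below may be only part of what the source reports. "The series", "measured", "known", "first", "only" and "open" are said of these compounds alone.

Measured in a functional assay on SK-BR-3 cells (Homo sapiens) for antiproliferative activity, read by MTT assay, with a stated time of 72 h; on this read-out lower numbers stand for stronger inhibition and higher numbers for weaker inhibition:
Compound 1 `CCN1CCN(c2cc(C)c3cc(NC(=O)c4ccc(F)cc4)ccc3n2)CC1`: 19800 nM
Compound 2 `CCN1CCN(c2cc(C)c3cc(NC(=O)c4cccc(C)c4)ccc3n2)CC1`: 13700 nM
Compound 3 `CCN1CCN(c2cc(C)c3cc(NC(=O)c4cc5ccccc5[nH]4)ccc3n2)CC1`: 2550 nM

Compound 3, at 2550 nM, has the lowest number of the three, and its gaps to the other two lie beyond the scatter. Compound 4 `CCN1CCN(c2cc(C)c3cc(NC(=O)c4cccc(F)c4)ccc3n2)CC1` keeps the shared core and differs from compound 3 in one group: 3-fluorophenyl in place of 1H-indol-2-yl on a carbonyl carbon. Here 3-fluorophenyl takes the place of 1H-indol-2-yl on a carbonyl carbon.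

For the measured compounds named here, two measured steps bear most directly on this change: a 7.8-fold lower number from compound 1 to compound 3 (0.89 log units; beyond the scatter) and a 5.4-fold lower number from compound 2 to compound 3 (0.73 log units; beyond the scatter). Both are modest, and both arrive at the 1H-indol-2-yl group from a group with one six-membered aromatic ring of carbon only. Compound 4 goes the opposite way. The third step, a 1.4-fold lower number from compound 1 to compound 2 (0.16 log units; within the scatter), stays within the scatter, so the two groups it compares give values that cannot be told apart. Going by the values given here, no measured compound carries 3-fluorophenyl itself, so the expectation rests on these comparisons alone. A modest rise of similar size is therefore expected in this assay. The estimated change is a 5.9-fold higher number from compound 3 to compound 4 (0.77 log units; beyond the scatter). For compound 4 the expected value is 15000 nM, with an estimated range of 7500 nM to 30000 nM.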

Compound 4, half-maximal inhibitory concentration: 24900 nM
Compound 4: the middle estimate sits 1.7-fold (0.22 log units) below what was measured; measured number inside the range.
By their numbers in this assay, from the lowest: compound 3; then compounds 2, 1 and 4 (each within the scatter of the next).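

In this assay the change from the 1H-indol-2-yl group to 3-fluorophenyl on the carbonyl carbon gives a 9.8-fold higher number from compound 3 to compound 4 (0.99 log units; beyond the scatter) and thereby extends the earlier picture to a third group with one six-membered aromatic ring of carbon only, so that compound 3 now stands apart from compounds 1, 2 and 4. Within that set of three the position shows no measurable preference, since fluoro in place of methyl on an aromatic carbon gives a 1.8-fold higher number from compound 2 to compound 4 (0.26 log units; within the scatter) and 3-fluorophenyl in place of 4-fluorophenyl gives a 1.3-fold higher number from compound 1 to compound 4 (0.10 log units; within the scatter) and both steps stay within the scatter. No measurement offered here accounts for the separate standing of the 1H-indol-2-yl group.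

It remains open which feature of that group goes with the lower number of compound 3, as it alone among these groups has a hydrogen-bond donor, a five-membered aromatic ring and a second ring. A naphthalen-2-yl group, a benzofuran-2-yl group or a 1-methyl-1H-indol-2-yl group on the same carbonyl carbon would separate these features, and these compounds do not show how any of them would behave.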